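The compounds below may be only part of what the source reports. "The series", "measured", "known", "first", "only" and "open" are said of these compounds alone.

Measured so far in a functional assay on HUVEC cells (Homo sapiens) for inhibition; a lower number here means a stronger inhibitor, a higher number a weaker inhibitor:
- Compound 1 `CC(=O)c1ccc(NC(=O)Nc2ccc(N(C)c3ccnc(Nc4cccc(CS(C)(=O)=O)c4)n3)cc2)cc1`: 2 nM
- Compound 2 `CN(c1ccc(NC(=O)NC2CCCC2)cc1)c1ccnc(Nc2cccc(CS(C)(=O)=O)c2)n1`: 1 nM

Compound 2, at 1 nM, sits within the scatter of compound 1, so neither of the two can be ranked above the other. Compound 3 `CN(C)CCNC(=O)Nc1ccc(N(C)c2ccnc(Nc3cccc(CS(C)(=O)=O)c3)n2)cc1` has 2-(dimethylamino)ethyl in place of cyclopentyl on an amide-type nitrogen. Going by the values given here, only one measured step bears on this change, since it falls at the same nitrogen: a 2.0-fold lower number from compound 1 to compound 2 (0.30 log units; within the scatter). That swap between two quite different groups left the number within the scatter, which suggests that the number in this assay may not respond strongly to a change here. However, this rests on a single pair, and no group without a ring has been measured at this nitrogen. No step beyond the scatter is therefore expected, with a slight lean towards a higher number and a wide margin on that side. The estimate amounts to a 2.0-fold higher number from compound 2 to compound 3 (0.30 log units; within the scatter). For compound 3 the expected value is 2 nM, with an estimated range from 0.7 nM to 8 nM.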

Compound 3, half-maximal inhibitory concentration: 530 nM
For compound 3 the middle estimate is 270-fold (2.42 log units) below the measured one; measured number above the stated range.
By their numbers in this assay, from the lowest: compounds 2 and 1 (each within the scatter of the next); then compound 3.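

In this assay, the group on this amide-type nitrogen turns out to matter a great deal: 2-(dimethylamino)ethyl in place of cyclopentyl gives a 530-fold higher number from compound 2 to compound 3 (2.72 log units; beyond the scatter), and the same group in place of 4-acetylphenyl gives a 270-fold higher number from compound 1 to compound 3 (2.42 log units; beyond the scatter). The near match between compound 1 and compound 2 therefore holds only for the two ring-bearing groups and does not extend to this open chain, which lies far from both. The compounds shown offer no evidence on why the step is so large.

Cyclopentyl and 2-(dimethylamino)ethyl differ in two ways at once, the loss of the ring and the entry of a nitrogen, so these compounds cannot say which of the two goes with the higher number. From the compounds shown here alone, a plain pentyl chain would speak to the ring, while a piperidin-4-yl ring or a longer 3-(dimethylamino)propyl chain would speak to the nitrogen and its place, and all of these remain open here.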